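Fluorine on the fused ring of a dimethoxy benzothiazole

The source may report more compounds than this note shows. Statements on the series, on what has been measured and on what is new or still open speak of the compounds shown alone.

Of the compounds shown here, three have been tested in a functional assay on HCC 2998 cells (Homo sapiens) for antiproliferative activity; a lower number here means a stronger inhibitor of growth, a higher number a weaker inhibitor of growth. Compound 1, `COc1ccc(-c2nc3ccccc3s2)cc1OC`, gives 42500 nM. Compound 2, `COc1ccc(-c2nc3cc(F)ccc3s2)cc1`, gives 12400 nM, and compound 3, `COc1ccc(-c2nc3cc(F)ccc3s2)cc1F`, gives 13700 nM. Compound 1 thus stands at the highest of the three numbers, beyond the scatter from both others. The difference between the core of compound 1 and the core of compound 2 is not broken down here.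

The change from compound 2 to compound 3 is fluoro in place of hydrogen on an aromatic carbon, and it moved the value by a 1.1-fold higher number from compound 2 to compound 3 (0.04 log units; within the scatter). Compound 4, `COc1ccc(-c2nc3c(F)cccc3s2)cc1OC`, carries the same kind of change against compound 1: fluoro in place of hydrogen on an aromatic carbon. The surroundings differ, however: in compound 3 the fluorine sits ortho to a methoxy group and meta to a large group, while in compound 4 it sits on a ring that is part of a fused system, ortho and meta to a fused ring. Going by the values given here, because the only comparable step, a 1.1-fold higher number from compound 2 to compound 3 (0.04 log units; within the scatter), lay within the scatter, compound 4 is expected to shift little, about a 1.1-fold lower number from compound 1 to compound 4 (0.03 log units; within the scatter). Compound 4 is therefore estimated at 40000 nM, between 15000 nM and 100000 nM.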

Compound 4, concentration for 50% growth inhibition: 1060 nM
Compound 4: middle estimate off by 38-fold (1.58 log units), on the high side; measured number below the stated range.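

In this assay, fluoro in place of hydrogen on an aromatic carbon gave a 40-fold lower number from compound 1 to compound 4 (1.60 log units; beyond the scatter), and the size of this step did not carry over from one core to the other: the same change on two cores in this assay, a 1.1-fold higher number (0.04 log units; within the scatter) from compound 2 to compound 3 and a 40-fold lower number (1.60 log units; beyond the scatter) from compound 1 to compound 4, 44-fold (1.65 log units) apart, beyond the scatter of two such steps

So this change cannot be treated as having one fixed effect in this series, and the result on one core gave no safe guide to the result on the other. What the two steps do not show is the reason for the gap, as they differ in more than the core: in compound 4 the fluoro sits on the ring that is part of a fused system, while in compound 3 it sits on the other ring, and two pairs cannot separate the site from the surrounding groups.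

The compounds shown leave open whether a chloro or a methyl group on the same carbon as the fluoro of compound 4 would give a similar step. They also leave open whether a fluoro on that carbon would have the same effect on the core of compound 2.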